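Methoxy in Place of Fluoro on a Shared Core

The source may hold more compounds than are shown below. What is called first, only, known or untested is meant among the compounds shown, and "the series" means these compounds.

Compound 1, `Nc1cc(N)c2nc(-c3ccccc3)c(Sc3ccc(F)cc3)nc2c1`, was tested in a functional assay on SF-539 cells (Homo sapiens) for inhibition, read by sulforhodamine B assay, with a stated time of 48 h (on this read-out lower numbers stand for higher toxicity in this test and higher numbers for lower toxicity in this test), where compound 1 gives 75900 nM. Among the compounds with values here, that is the only actual number in this small set. Compound 2, `CCOC(=O)[C@H](CCC(=O)O)NC(=O)c1ccc(Oc2nc3cc(N)cc(N)c3nc2-c2ccccc2)cc1`, returns only a limit of the test, reported as < 100000 nM, which is a boundary of the measurement rather than a number. Compound 3, `CCOC(=O)[C@H](CCC(=O)O)NC(=O)c1ccc(CNc2nc3cc(N)cc(N)c3nc2-c2ccccc2)cc1`, likewise returns only < 100000 nM, again a limit and not a number. Among the values shown, compound 1 therefore stands alone as a measured figure, while the limit of < 100000 nM in this assay, at which 2 of the 3 values shown sit, marks where the other two sit.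

Compound 4, `COc1ccc(Sc2nc3cc(N)cc(N)c3nc2-c2ccccc2)cc1`, has not yet been measured. It differs from compound 1 in one place: methoxy in place of fluoro on an aromatic carbon. Within the data shown here, no pair of measured compounds here differs by a single change, so there is no measured step to lean on. Exchanging one small group for another on the same aromatic carbon, with the rest of the molecule unchanged, is expected to move the read-out little, if at all, beyond the usual scatter. The expected step, a 1.1-fold lower number from compound 1 to compound 4 (0.04 log units; within the scatter), is roughly flat. Compound 4 is accordingly expected to give about 70000 nM, within a range of 30000 nM to 150000 nM.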

Compound 4, concentration lethal to 50% of the cells: < 100000 nM
Compound 4: only a limit was reported; the forecaster's own chance of this, stated with the estimate: 25%; the middle value does not contradict the limit.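

Compound 4 gives < 100000 nM, which is a limit of the test and not a number. No step from compound 1 to compound 4 can be read, because compound 4 has only this limit to compare: the limit of < 100000 nM in this assay, at which 3 of the 4 values shown sit.

The compounds shown leave open whether methoxy in place of fluoro changes the read-out at all, and by how much.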